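The source may hold more compounds than are shown below. What is called first, only, known or untested is meant among the compounds shown, and "the series" means these compounds.

In a functional assay on OVCAR cells (Homo sapiens) for cytotoxicity, read by sulforhodamine B assay, with a stated time of 48 h (a lower number here means a stronger inhibitor, a higher number a weaker inhibitor), compound 1 `CC(=O)N1N=C(c2cccc3ccccc23)CC1/C=C/c1ccccc1` gives 24000 nM, and compound 2 `O=CCN1N=C(c2ccc3ccccc3c2)CC1c1cccc([N+](=O)[O-])c1` gives 3390 nM. Compound 2 holds the lower of the two numbers, separated from compound 1 by a gap beyond the scatter. Compound 3 `O=CCN1N=C(c2ccc3ccccc3c2)CC1c1ccco1` carries the change (furan-2-yl in place of 3-nitrophenyl on a saturated ring carbon), a furan-2-yl in place of 3-nitrophenyl on a saturated ring carbon. Within the data shown here, no measured pair shows this change, so the expected step from compound 2 to compound 3 is set at a 2.1-fold higher number from compound 2 to compound 3 (0.31 log units; beyond the scatter), a modest move toward a higher number, resting on no measured step. For compound 3 in this assay the estimate is 7000 nM, within 2500 nM to 25000 nM.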

Compound 3, half-maximal inhibitory concentration: 18000 nM
Compound 3: the middle estimate sits 2.6-fold (0.41 log units) below what was measured; low and high end bracket the measured number.
By their numbers in this assay, from the lowest: compound 2; then compounds 3 and 1 (each within the scatter of the next).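

At the saturated ring carbon next to the ring nitrogen, furan-2-yl in place of 3-nitrophenyl gives a weaker inhibitor in this assay, with a 5.3-fold higher number from compound 2 to compound 3 (0.73 log units; beyond the scatter). This position is therefore sensitive to the group it carries, and of these two groups 3-nitrophenyl gives the lower number. Nothing on hand explains this step.

The two compounds do not separate the contribution of the nitro group from that of the six-membered ring. Going by these compounds, how a plain phenyl or a 3-aminophenyl would compare at this carbon remains open.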